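The compounds below may be only part of what the source reports. "The series", "measured", "known", "first", "only" and "open" are said of these compounds alone.

Measured compounds:
compound 1 `CNS(=O)(=O)c1ccc(-c2cnc(N)c(-c3ccc(OC)nc3)c2)cc1` — 12.5 ug/mL
compound 2 `COc1ccc(-c2cc(-c3ccc(-n4cccn4)cc3)cnc2N)cn1` — 3.1 ug/mL

In a physicochemical assay for solubility, read by nephelometry, in phosphate buffer, measured as kinetic solubility, at pH 6.5 (on this read-out lower numbers stand for lower solubility and higher numbers for higher solubility), compound 2 stands lowest of the two numbers; its nearest neighbour is compound 1, which gives 12.5 ug/mL. The step to compound 3 `CNC(=O)c1ccc(-c2cnc(N)c(-c3ccc(OC)nc3)c2)cc1` is methylcarbamoyl in place of 1H-pyrazol-1-yl on an aromatic carbon. Among the measured compounds shown here, one measured step bears on it: a 4.0-fold lower number from compound 1 to compound 2 (0.61 log units; beyond the scatter), where a group carrying a hydrogen-bond donor left and the 1H-pyrazol-1-yl group entered, and the number fell. The present change removes that same 1H-pyrazol-1-yl group and brings in methylcarbamoyl, which again carries 1 hydrogen-bond donor and 1 hydrogen-bond acceptor, so a step back upward of roughly the same size is expected in this assay. Compound 3 is therefore estimated at 11 ug/mL, with a range from 4.5 ug/mL to 27 ug/mL. That estimate amounts to an expected 3.5-fold higher number from compound 2 to compound 3 (0.55 log units; beyond the scatter).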

Compound 3, solubility: 50 ug/mL
For compound 3 the middle estimate is 4.5-fold (0.66 log units) below the measured one; the measured number lies above the stated range.
By their numbers in this assay, from the lowest: compound 2; then compound 1; then compound 3.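

In this assay, among the compounds shown here, methylcarbamoyl in place of 1H-pyrazol-1-yl on this aromatic carbon, para to a large group, gives a 16-fold higher number from compound 2 to compound 3 (1.21 log units; beyond the scatter), so the spread of numbers at this position is wider than the single earlier step showed. The two groups that carry a hydrogen-bond donor also do not stand level: methylcarbamoyl in place of methylsulfamoyl gives a 4.0-fold higher number from compound 1 to compound 3 (0.60 log units; beyond the scatter), so having a donor on this carbon does not by itself fix the number. Nothing given here explains why the amide stands above the sulfonamide.

On these data alone, it remains open where other groups at this position, such as a carboxylic acid, an amine or a longer amide chain, would fall in this order. As far as these compounds go, all three compounds share one core, so whether the order holds on another core is also open.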